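Amino in place of hydrogen on a fused aromatic core

This account rests on a few compounds, and the source may have more. Where it says the series, first, only, none or still open, it means among the compounds named here.

Measured so far:
compound 1, `ClCc1ccc(Cn2cnc3c(Cl)ncnc32)cc1`: 11800 nM
compound 2, `ClCc1ccccc1Cn1cnc2c(Cl)nc(Cl)nc21`: 2950 nM

In a functional assay on DU-145 cells (Homo sapiens) for cytotoxicity, read by sulforhodamine B assay, with a stated time of 48 h (on this read-out lower numbers stand for stronger inhibition of growth and higher numbers for weaker inhibition of growth), compound 1 gives 11800 nM, the higher of the two numbers recorded so far, and so the weaker of the two growth inhibitors. In this assay compound 2 gives 2950 nM, a lower number that lies beyond the usual scatter, but the two differ in more than one place, so their gap cannot be traced to a single change.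

Compound 3, `Nc1nc(Cl)c2ncn(Cc3ccc(CCl)cc3)c2n1`, has not yet been measured in this assay. It differs from compound 1 in one place: amino in place of hydrogen on an aromatic carbon. The amino group sits on an aromatic carbon between two ring nitrogen atoms of the fused core, meta to the chloro group. Nothing recorded so far shows what this exchange does on its own, so the step is expected to be small, with no clear direction beyond the scatter; a modest move to a lower number seems as likely as no move at all. Compound 3 is estimated at 8000 nM, within 2500 nM to 25000 nM, which corresponds to an expected step of a 1.5-fold lower number from compound 1 to compound 3 (0.17 log units; within the scatter).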

Compound 3, concentration for total growth inhibition: 19500 nM
Estimate against measurement, compound 3: 2.4-fold (0.39 log units) below; measured number inside the range.
By their numbers in this assay, from the lowest: compound 2; then compounds 1 and 3 (each within the scatter of the next).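

In this assay the exchange of hydrogen for amino, on the aromatic carbon between two ring nitrogen atoms of the shared core, gives a 1.7-fold higher number from compound 1 to compound 3 (0.22 log units; within the scatter) and so stays inside the range that repeated measurements of a single compound can cover. Going by these compounds alone, this is the first view of this position on its own, since the only earlier pair differs in more than one place. It shows that, with the rest of the structure held fixed, adding this one group with its hydrogen-bond donor and acceptor produces no step that can be told apart from the scatter on this read-out, and no measurement on hand offers an explanation for this result.

Still open, going by these compounds, is whether a different group on this same carbon, such as methylamino, dimethylamino or hydroxyl, would produce a step beyond the scatter. Also open, on these data alone, is whether amino would behave the same way on a compound that carries a methyl group in place of the chloromethyl group.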